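Methyl on the aminopyridine: permeability estimate for compound 4

The source may hold more compounds than are shown below. What is called first, only, known or untested is meant among the compounds shown, and "the series" means these compounds.

Measured compounds:
compound 1 `O=C(Nc1cccnc1)c1cccc(Oc2ccc3c(c2)c(=O)ncn3Cc2c(F)cc(F)cc2F)c1C(F)(F)F`: 0.26 10^-6 cm/s
compound 2 `O=C(Nc1ccccn1)c1cccc(Oc2ccc3c(c2)c(=O)ncn3Cc2c(F)cc(F)cc2F)c1C(F)(F)F`: 1.2 10^-6 cm/s
compound 3 `Nc1ccc(-c2cccc(Oc3ccc4c(c3)c(=O)ncn4Cc3c(F)cc(F)cc3F)c2C(F)(F)F)cn1`: 4.1 10^-6 cm/s

The three compounds were examined in an ADME assay on Caco-2 cells (Homo sapiens) for permeability, in the apical to basolateral direction; on this read-out lower numbers stand for lower permeability and higher numbers for higher permeability. Compound 3 stands highest of the three: compound 2 lies nearest, a 3.4-fold higher number from compound 2 to compound 3 (0.53 log units; beyond the scatter), and compound 1 lies furthest, a 16-fold higher number from compound 1 to compound 3 (1.20 log units; beyond the scatter). Between the two amides, the step of a 4.6-fold higher number from compound 1 to compound 2 (0.66 log units; beyond the scatter) is modest.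

Compound 4 `Cc1cc(-c2cccc(Oc3ccc4c(c3)c(=O)ncn4Cc3c(F)cc(F)cc3F)c2C(F)(F)F)cnc1N` differs from compound 3 by methyl in place of hydrogen on an aromatic carbon. Among the compounds with values here, none of the measured steps bears directly on this change: all three concern the replacement of an amide-type linkage by the 6-aminopyridin-3-yl group or the exchange of one pyridyl for another on the amide nitrogen, and each of them changes a large part of the molecule, whereas the step to compound 4 adds a single carbon to a group already present. The measured steps therefore give no firm direction, and the expected step in this assay is small.

For compound 4 the expectation is a number close to that of compound 3, a 1.3-fold higher number from compound 3 to compound 4 (0.13 log units; within the scatter), within the usual scatter, estimated at 5.5 10^-6 cm/s, with a range from 2.5 10^-6 cm/s to 12 10^-6 cm/s.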

Compound 4, apparent permeability: 1.1 10^-6 cm/s
Compound 4: the middle estimate sits 5.0-fold (0.70 log units) above what was measured; the whole stated range lies above it.
By their numbers in this assay, from the lowest: compound 1; then compounds 4 and 2 (each within the scatter of the next); then compound 3.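

In this assay, within the data shown here, the earlier compounds left this ring position unvaried, and the first change made there, a methyl on an aromatic carbon ortho to the amino group and two atoms from the ring nitrogen, is a modest step beyond the scatter (a 3.7-fold lower number from compound 3 to compound 4 (0.57 log units; beyond the scatter)). With 6-amino-5-methylpyridin-3-yl in place, the gap to the pyridin-2-yl amide falls within the scatter (a 1.1-fold lower number from compound 2 to compound 4 (0.04 log units; within the scatter)), while the gap to the pyridin-3-yl amide remains beyond it (a 4.2-fold higher number from compound 1 to compound 4 (0.63 log units; beyond the scatter)), so the addition of one carbon removes one of the two separations that 6-aminopyridin-3-yl held over the amides. Nothing at hand explains why this single methyl gives a step of this size.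

The compounds leave open whether the step is specific to methyl or would also appear with another group on the same carbon, such as an ethyl group, a chlorine atom or a methoxy group. They also leave open whether a methyl elsewhere on this ring, or a methyl on the amino nitrogen, would give a similar step.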